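The compounds below may be only part of what the source reports. "The series", "measured", "known", "first", "only" and "open" are said of these compounds alone.

Compound 3 `CCCn1c(=O)n(C)c(=O)c2c1ncn2CCOC` gives the lowest of the two numbers obtained in an assay on Cerebral cortex for binding affinity to adenosine receptor A1 (Cavia porcellus), read by radioligand binding (a higher number here means a weaker inhibitor, a lower number a stronger inhibitor), at 12400 nM. Compound 1 `CCCn1c(=O)n(C)c(=O)c2c1ncn2CCC#N` gives 88600 nM in this assay, and the change between them reads a 7.1-fold lower number from compound 1 to compound 3 (0.85 log units; beyond the scatter). Compound 2 `CCCn1c(=O)n(C)c(=O)c2c1ncn2CCN(C)C` sits at the limit of > 200000 nM in this assay, at which 1 of the 3 values shown sits, of this assay, reported as > 200000 nM. From that limit the step is an at least 16-fold lower number from compound 2 to compound 3 (1.20 log units; beyond the scatter). Compound 4 `CCCn1c(=O)n(C)c(=O)c2c1ncn2CCC(C)=O` differs from compound 3 by acetyl in place of methoxy on a saturated chain carbon, two bonds along the chain from an aromatic nitrogen. Going by the values given here, no measured step exchanges methoxy for acetyl; the steps of a 7.1-fold lower number from compound 1 to compound 3 (0.85 log units; beyond the scatter) and an at least 16-fold lower number from compound 2 to compound 3 (1.20 log units; beyond the scatter) both show methoxy giving the lowest number in this place, so a modest rise is expected for compound 4. Compound 4 is therefore estimated at 40000 nM in this assay, between 12000 nM and 130000 nM. That estimate means an expected step of a 3.2-fold higher number from compound 3 to compound 4 (0.51 log units; beyond the scatter).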

Compound 4, inhibition constant: 30000 nM
The estimate for compound 4 lay 1.3-fold (0.12 log units) above the measured number, and the stated range covers the measured number.
By their numbers in this assay, from the lowest: compound 3; then compound 4; then compound 1. At a limit, above all of these: compound 2.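

Methoxy keeps the lowest number at this place in this assay, but acetyl gives up only part of that advantage, with a 2.4-fold higher number from compound 3 to compound 4 (0.38 log units; beyond the scatter). Acetyl still stands clear of cyano, with a 3.0-fold lower number from compound 1 to compound 4 (0.47 log units; beyond the scatter), which places it in the middle of the three groups with exact values. The dimethylamino value is a limit, so its comparison with acetyl gives only a bound, with an at least 6.6-fold lower number from compound 2 to compound 4 (0.82 log units; beyond the scatter).

As far as these compounds go, what a carboxylic acid, a primary amide or a longer chain would give at this place stays open. From the compounds shown here alone, whether this order holds with other groups elsewhere on the shared core also stays open.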